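Swapping the Sulfonamide Aryl Group in a Cytotoxicity Series

The source may hold more compounds than are shown below. What is called first, only, known or untested is meant among the compounds shown, and "the series" means these compounds.

Compound 1: `CC1CCN(C2CCN(S(=O)(=O)c3cccc(N)c3)CC2)CC1` — > 5000 nM
Compound 2: `CC1CCN(C2CCN(S(=O)(=O)c3cccc(-c4ccc(F)cc4)c3)CC2)CC1` — > 5000 nM
Compound 3: `CC1CCN(C2CCN(S(=O)(=O)c3cccc(-c4ccccc4C(F)(F)F)c3)CC2)CC1` — > 5000 nM

All three measured compounds share a core in which a sulfonyl sulfur carries an aromatic ring, and they were tested in an ADME assay on HCT-116 cells (Homo sapiens) for cytotoxicity, read by CellTiter-Glo, with a stated time of 72 h; a higher number here means a weaker inhibitor, a lower number a stronger inhibitor. Compound 1 sits at a limit of the assay, > 5000 nM, rather than at a number. Compound 2 also sits at a limit, > 5000 nM. Compound 3 sits at the same limit, > 5000 nM. The measured steps are therefore unreadable: a step that the two limits leave unreadable from compound 1 to compound 2, a step that the two limits leave unreadable from compound 1 to compound 3 and a step that the two limits leave unreadable from compound 2 to compound 3 each run between two limits, so their size cannot be told. What the data do show is the limit of > 5000 nM in this assay, at which 3 of the 3 values shown sit.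

Compound 4, `CC1CCN(C2CCN(S(=O)(=O)c3cncc(Br)c3)CC2)CC1`, has not yet been measured in this assay. It differs from compound 1 by 5-bromopyridin-3-yl in place of 3-aminophenyl on a sulfonyl sulfur.

For the measured compounds named here, none of the measured steps reaches a readable number, so no direction can be taken from them; the only guide is that every tested ring on the sulfonyl sulfur stayed at the limit. Compound 4 is therefore expected to remain there as well, and the step that the limit leaves unreadable from compound 1 to compound 4 is estimated to be none beyond the scatter. The estimate for compound 4 in this assay is 8000 nM, with a range from 3000 nM to 30000 nM.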

Compound 4, half-maximal inhibitory concentration: > 10000 nM
Compound 4 ended at the assay's limit; the forecaster's own chance of this, stated with the estimate: 85%; middle value at least 1.2-fold (0.09 log units) from the limit.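

In this assay compound 4 gives > 10000 nM, which is a limit of the assay and not a number. Compound 1 also stands at a limit, so no size can be read for the change from compound 1 to compound 4. The compounds shown leave open whether any group on the sulfonyl sulfur can give a true number in this assay.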